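Methoxy on compound 3, a member of an inactive set

The source may report more compounds than this note shows. Statements on the series, on what has been measured and on what is new or still open speak of the compounds shown alone.

In a functional assay on PC-3 cells (Homo sapiens) for cytotoxicity, read by MTT assay, with a stated time of 24 h (on this read-out lower numbers stand for stronger inhibition and higher numbers for weaker inhibition), compound 3 (`C=C1CC[C@H](C)[C@@](C)(CCC2=CCOC2=O)C/C=C\C=C/1C(=O)O`) gives > 40000 nM, which is a limit and not a number. Compound 1 (`C=C1CC[C@H](C)[C@@](C)(CCC2=CC(OCC)OC2=O)C/C=C\C=C/1C(=O)O`) gives > 40000 nM, also a limit. Compound 2 (`C=C1CC[C@H](C)[C@@](C)(CCC2=CC(O)OC2=O)C/C=C\C=C/1C(=O)O`) gives > 40000 nM, again a limit. Compound 3 thus offers no measured number to start from, and the set stands at the limit of > 40000 nM in this assay, at which 3 of the 3 values shown sit.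

Compound 4 (`C=C1CC[C@H](C)[C@@](C)(CCC2=CC(OC)OC2=O)C/C=C\C=C/1C(=O)O`) has methoxy in place of hydrogen on a saturated ring carbon, next to the ring oxygen: methoxy in place of hydrogen on a saturated ring carbon.

Among the measured compounds shown here, three measured steps bear on this change. Ethoxy gives way to hydrogen in a step that the two limits leave unreadable from compound 1 to compound 3, hydroxy gives way to hydrogen in a step that the two limits leave unreadable from compound 2 to compound 3, and the ethyl is lost in a step that the two limits leave unreadable from compound 1 to compound 2. None of them offers a size or direction to carry over, but all three compounds remain at the limit, and compound 4 is expected to do the same. The expected change is a step that the limit leaves unreadable from compound 3 to compound 4, with no direction expected. Compound 4 is estimated at 60000 nM, with an expected range of 40000 nM to 100000 nM.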

Compound 4, half-maximal inhibitory concentration: > 40000 nM
Compound 4: no number, only a limit; the forecaster's own chance of this, stated with the estimate: 90%; the middle value is on the limit's open side.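

Compound 4 gives > 40000 nM in this assay, which is a limit and not a number, so its steps from compound 1, compound 2 and compound 3 cannot be read. The compounds shown leave open whether the group on the saturated ring carbon changes the read-out at all: the limit of > 40000 nM in this assay, at which 4 of the 4 values shown sit.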